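From Nitrile to (Dimethylamino)methyl: an Estimate

A few compounds are considered here, and "the series" means these few. Any claim that something is new, unique, unknown or untested is made for them only; others in the source may bear on it.

Compound 3 `CC(C)(C)c1ccc(NC(=O)c2ccc(-c3ncccc3C#N)cc2)cc1` is an amide on a shared core; in a functional assay for antagonist activity at transient receptor potential cation channel subfamily V member 1 (Rattus norvegicus) (a lower number here means a stronger inhibitor, a higher number a weaker inhibitor), compound 3 gives 13 nM. Compound 1 `C[C@@H]1CN(c2ncccc2C(F)(F)F)CCN1C(=O)Nc1ccc(C(F)(F)F)cc1`, built on a different core, gives 11 nM in this assay, so compound 3 holds the higher of the two numbers, the gap between them lying within the usual scatter. Compound 2 `Cc1cccnc1-c1ccc(C(=O)Nc2ccc(F)cc2)cc1` is recorded in this assay only as a limit, > 4000 nM (the limit of > 4000 nM in this assay, at which 1 of the 3 values shown sits). Compound 4 `CN(C)Cc1cccnc1-c1ccc(C(=O)Nc2ccc(C(C)(C)C)cc2)cc1` differs from compound 3 in one place: (dimethylamino)methyl in place of cyano on an aromatic carbon. Among the compounds with values here, no measured pair shows this kind of change, so the expectation rests on compound 3 alone, at 13 nM. A weakening step of a 7.7-fold higher number from compound 3 to compound 4 (0.89 log units; beyond the scatter) is expected, and compound 4 is estimated at 100 nM, within 20 nM to 600 nM.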

Compound 4, half-maximal inhibitory concentration: 234 nM
Beside the measured number, compound 4's estimate is 2.3-fold (0.37 log units) below it; the range from low to high includes it.
By their numbers in this assay, from the lowest: compounds 1 and 3 (each within the scatter of the next); then compound 4. At a limit, above all of these: compound 2.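

This position, on an aromatic carbon ortho to a large group and two atoms from the ring nitrogen, is sensitive to what it carries: (dimethylamino)methyl in place of cyano gives an 18-fold higher number from compound 3 to compound 4 (1.26 log units; beyond the scatter). Even so, in this assay compound 4 gives 234 nM, a measured number and not a limit. Nothing shown here accounts for the size of this step.

With only these two groups compared at this position, the cause of the step stays open. So does where an aminomethyl group or a carboxylic acid would fall.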